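Bromoacetyl in place of 1-bromoethylcarbonyl: compound 1 to compound 4

The compounds below may be only part of what the source reports. "The series", "measured", "known", "first", "only" and "open" are said of these compounds alone.

Measured in a functional assay on CCRF-CEM cells (Homo sapiens) for antiproliferative activity, read by trypan blue exclusion, with a stated time of 72 h; a higher number here means a weaker inhibitor, a lower number a stronger inhibitor:
- compound 1 `Cc1ccc(C(=O)NC(N)=O)cc1NC(=O)C(C)Br`: 3360 nM
- compound 2 `CC(Br)C(=O)Nc1cc(C(=O)NC(N)=O)ccc1Cl`: 9800 nM
- compound 3 `COc1ccc(C(=O)NC(N)=O)cc1NC(=O)C(C)Br`: > 20000 nM (a limit of the assay, not a number)

Compound 1 holds the lowest of the two actual numbers, and its nearest neighbour gives a 2.9-fold higher number from compound 1 to compound 2 (0.46 log units; beyond the scatter). The value of compound 3 is only a limit, which leaves an at least 5.9-fold higher number from compound 1 to compound 3 (0.77 log units; beyond the scatter) as a floor.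

Compound 4 `Cc1ccc(C(=O)NC(N)=O)cc1NC(=O)CBr` keeps the core of compound 1 and has hydrogen in place of methyl on a saturated chain carbon bound to a bromine atom and a carbonyl carbon.

Among the measured compounds shown here, no measured step touches this place. All three lie on an aromatic carbon, and an at least 2.0-fold higher number from compound 2 to compound 3 (0.30 log units; that floor lies within the scatter) adds little, so a 2.9-fold higher number from compound 1 to compound 2 (0.46 log units; beyond the scatter) and an at least 5.9-fold higher number from compound 1 to compound 3 (0.77 log units; beyond the scatter) serve only as a guide to size. A modest move towards a lower number is expected, though the direction remains a judgement.

The expected change is a 3.4-fold lower number from compound 1 to compound 4 (0.53 log units; beyond the scatter).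

Compound 4 is estimated at 1000 nM, with an expected range of 200 nM to 4000 nM.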

Compound 4, half-maximal inhibitory concentration: 4280 nM
Compound 4: the middle estimate sits 4.3-fold (0.63 log units) below what was measured; the measured number lies above the stated range.
By their numbers in this assay, from the lowest: compounds 1 and 4 (each within the scatter of the next); then compound 2. At a limit, above all of these: compound 3.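

In this assay, hydrogen in place of methyl on a saturated chain carbon bound to a bromine atom and a carbonyl carbon gives a 1.3-fold higher number from compound 1 to compound 4 (0.11 log units; within the scatter), so this assay does not separate (1-bromoethyl)carbonyl from (bromomethyl)carbonyl on the core of compound 1. The earlier steps shown here all lay on an aromatic carbon, whereas this first step on the chain shows that the methyl can go without a change beyond the scatter. Nothing given here accounts for this result.

The change is shown only with the methyl on the aromatic carbon, so its outcome with the chloro of compound 2 or the methoxy of compound 3 remains open. Also open, on these data alone, is what an ethyl group on the chain carbon, or a chlorine atom in place of the bromine atom, would do to the number.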